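Chain Extension on an Iodoacetamide Triphosphate Probe

The source may hold more compounds than are shown below. What is called first, only, known or untested is meant among the compounds shown, and "the series" means these compounds.

Compound 1 `Nc1ncnc2c1nc(NCCCCNC(=O)CI)n2[C@@H]1O[C@H](COP(=O)(O)OP(=O)(O)OP(=O)(O)O)[C@@H](O)[C@H]1O` gives 0% in an assay on isolated protein for inhibition of hexokinase-2 (Rattus norvegicus), with a stated time of 6 h, tested at 10 mM; on this read-out higher numbers stand for more inhibition at the one concentration tested (going by the name of the read-out) and lower numbers for less inhibition. It stands level with compound 2 `O=C(CI)NCCCNc1ncnc2c1ncn2[C@@H]1O[C@H](COP(=O)(O)OP(=O)(O)OP(=O)(O)O)[C@@H](O)[C@H]1O`, which gives 0%, and with compound 3 `CN(CCCCN(C)c1ncnc2c1ncn2[C@@H]1O[C@H](COP(=O)(O)OP(=O)(O)OP(=O)(O)O)[C@@H](O)[C@H]1O)C(=O)CCCCCNC(=O)CI`, which gives 0%; all three values lie within the usual scatter of one another, so nothing separates them. Compound 4 `Nc1ncnc2c1nc(NCCCCCCCCNC(=O)CI)n2[C@@H]1O[C@H](COP(=O)(O)OP(=O)(O)OP(=O)(O)O)[C@@H](O)[C@H]1O` has not yet been measured. It differs from compound 1 in one place: 4-(((iodomethyl)carbonyl)amino)butyl in place of ((iodomethyl)carbonyl)amino on a saturated chain carbon, four bonds along the chain from a nitrogen on an aromatic ring. Within the data shown here, no comparable step between measured compounds exists, and every measured compound sits at the same level. The step from compound 1 to compound 4 is therefore expected to be a number 2 percentage points higher from compound 1 to compound 4 (within the scatter), none beyond the scatter, because compound 1 gives 0%. Compound 4 is estimated to give 2%, with a range from 0% to 12%.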

Compound 4, a percentage reported as inhibition, at one concentration (the size of the read-out at that concentration, not a potency): 0%
The estimate for compound 4 lay 2 percentage points above the measured number; low and high end bracket the measured number.
By their numbers in this assay, from the lowest: compounds 1, 2, 3 and 4 (each within the scatter of the next).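

In this assay, 4-(((iodomethyl)carbonyl)amino)butyl in place of ((iodomethyl)carbonyl)amino at this place shows no change at the digits printed from compound 1 to compound 4 (within the scatter). Among these compounds, this is the first step here that compares two compounds differing in one place, and it shows that this extension of the chain leaves the read-out at the level of the other compounds. Nothing available here accounts for this result.

As far as these compounds go, whether a still longer chain at this place would move the number remains open. So does the effect of an amine or a carboxylic acid in place of the ((iodomethyl)carbonyl)amino end.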